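The source may report more compounds than this note shows. Statements on the series, on what has been measured and on what is new or still open speak of the compounds shown alone.

In a functional assay on HeLa cells (Homo sapiens) for cytotoxicity, read by sulforhodamine B assay (on this read-out higher numbers stand for weaker inhibition and lower numbers for stronger inhibition), compound 1 `COc1ccc2c(c1)CCCN2c1nc(C)nc2ccccc12` gives 1.2 nM. Compound 2 `CSc1ccc(N(C)c2nc(C)nc3ccccc23)cc1` gives 1.1 nM, within the scatter of compound 1, while compound 3 `COc1ccc(N(C)c2ncnc3ccccc23)cc1` gives 7.4 nM, a higher number beyond the scatter. Compound 1 therefore stands level with compound 2 at the strongly inhibiting end of these three numbers.

Compound 4 `COc1ccc2c(c1)CCCN2c1ncnc2ccccc12`, not yet measured, has hydrogen in place of methyl on an aromatic carbon of compound 1, at the place between two ring nitrogen atoms: hydrogen in place of methyl on an aromatic carbon. Among the measured compounds shown here, no measured pair isolates this change. Compounds 1 and 2 carry the methyl there, whereas compound 3 carries hydrogen, although compound 3 also differs from both elsewhere. With that caution, a step beyond the scatter towards weaker inhibition is expected in this assay, since compound 3 gives 7.4 nM. The expected change is the estimated step of a 5.0-fold higher number from compound 1 to compound 4 (0.70 log units; beyond the scatter). Compound 4 is expected at about 6 nM, with an estimated range of 2 nM to 20 nM.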

Compound 4, half-maximal inhibitory concentration: 13.1 nM
Compound 4: the middle estimate sits 2.2-fold (0.34 log units) below what was measured, within the range that was stated.
By their numbers in this assay, from the lowest: compounds 2 and 1 (each within the scatter of the next); then compounds 3 and 4 (each within the scatter of the next).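

Among the compounds shown here, compounds 1 and 4 form the first pair that isolates this change: in this assay, hydrogen in place of methyl on the aromatic carbon between two ring nitrogen atoms gives an 11-fold higher number from compound 1 to compound 4 (1.04 log units; beyond the scatter), a large step towards weaker inhibition. For the compounds shown here, the earlier compounds offered no pair differing only here, so this step is the first direct sign that the methyl at this place matters for the low number of compound 1. Nothing in the data given bears on why the step arises.

Going by these compounds, only methyl and hydrogen are compared at this place, so it remains open how an ethyl group, an amine or a chlorine atom there would compare with the methyl of compound 1. On these data alone, whether the same change would give a step of like size on compound 2 also remains open.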